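The source may hold more compounds than are shown below. What is called first, only, known or untested is meant among the compounds shown, and "the series" means these compounds.

Series notes. Compound 1 `Nc1scc(CN2CCN(c3ccc(OC(F)(F)F)cc3)CC2)c1C(=O)c1ccc(Cl)cc1` gives -74% in a functional assay on CHO cells with adenosine receptor A1 (Homo sapiens) as the target, read by cAMP accumulation and immunoassay, with a stated time of 6 min, tested at 10 uM (on this read-out higher numbers stand for a weaker effect at the one concentration tested and lower numbers for a stronger effect), the lowest of the two numbers recorded so far. Compound 2 `Nc1scc(CN2CCN(c3cccc(F)c3)CC2)c1C(=O)c1cccc(C(F)(F)F)c1` gives -62% in this assay, a reading higher than that of compound 1 by more than the usual scatter. Compound 3 `Nc1scc(CN2CCN(c3ccc(F)c(Cl)c3)CC2)c1C(=O)c1ccc(Cl)cc1` is not yet measured; it differs from compound 1 by 3-chloro-4-fluorophenyl in place of 4-(trifluoromethoxy)phenyl on an amine nitrogen in a ring. Among the compounds with values here, no pair of measured compounds isolates this change, so in this assay only a modest shift toward a less negative reading is expected, if any beyond the scatter. For compound 3 the expected value in this assay is -65%, within -85% to -40%, an expected step of a number 9 percentage points higher from compound 1 to compound 3 (within the scatter).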

Compound 3, a percentage reported as activity, at one concentration (the size of the read-out at that concentration, not a potency): -78%
Beside the measured number, compound 3's estimate is 13 percentage points above it, and the stated range covers the measured number.
By their numbers in this assay, from the lowest: compounds 3 and 1 (each within the scatter of the next); then compound 2.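

On an amine nitrogen in a ring, 3-chloro-4-fluorophenyl in place of 4-(trifluoromethoxy)phenyl gives a number 4 percentage points lower from compound 1 to compound 3 (within the scatter) in this assay. Within the data shown here, this is the first single-place change, and at this position the two substituted phenyl groups cannot be told apart on this read-out. Nothing at hand explains this result.

Going by these compounds, whether an unsubstituted phenyl, a pyridine or a benzyl group on that nitrogen would give a similar reading remains open.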